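Methoxyphenyl sulfonamides: positional isomer on the sulfonyl ring

This account rests on a few compounds, and the source may have more. Where it says the series, first, only, none or still open, it means among the compounds named here.

Measured so far in an assay on cells for inhibition of HSP60/HSP10 (Homo sapiens), with a stated time of 60 min; on this read-out lower numbers stand for stronger inhibition and higher numbers for weaker inhibition:
compound 1 `O=S(=O)(Nc1ccc2oc(-c3ccccc3)nc2c1)c1cccc(C(F)(F)F)c1`: > 100000 nM
compound 2 `COc1cccc(S(=O)(=O)Nc2ccc3oc(-c4ccccc4)nc3c2)c1`: > 100000 nM

Compound 2 stands only at a limit of this assay, not at a number. The same holds for compound 1, whose value is also a limit. Among the measured compounds shown here, the one measured step, a step that the two limits leave unreadable from compound 1 to compound 2, is therefore unreadable in size; the limit of > 100000 nM in this assay, at which 2 of the 2 values shown sit, shows that both values shown sit there.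

Compound 3 `COc1ccc(S(=O)(=O)Nc2ccc3oc(-c4ccccc4)nc3c2)cc1` is the positional isomer of compound 2: 4-methoxyphenyl in place of 3-methoxyphenyl on a sulfonyl sulfur. For the measured compounds named here, the only step that bears on it is the unreadable one from compound 1 to compound 2, so no direction or size can be drawn from the numbers for compound 3. Given that both values rest at the limit, the step that the limit leaves unreadable from compound 2 to compound 3 is expected to be nothing beyond the scatter, most likely another limit. Compound 3 is therefore estimated at 150000 nM, within 40000 nM to 1000000 nM.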

Compound 3, half-maximal inhibitory concentration: > 100000 nM
Compound 3 gave a limit, no number (the forecaster's own chance of this, stated with the estimate: 85%); the middle value is on the limit's open side.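

No step can be read among compound 1, compound 2 and compound 3, since each value is a limit and not a number: the limit of > 100000 nM in this assay, at which 3 of the 3 values shown sit.

The compounds shown leave open whether 3-methoxyphenyl and 4-methoxyphenyl differ at all in this assay, and what on the shared core would give a measurable value.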